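Acyl branching on the disaccharide ester: isopropyl to isobutyl

This account rests on a few compounds, and the source may have more. Where it says the series, first, only, none or still open, it means among the compounds named here.

The study starts from compound 1 `CCCCCCCCO[C@@H]1O[C@@H](C)[C@H](OC(=O)CCCCC)[C@@H](O[C@@H]2O[C@@H](C)[C@H](OC(C)=O)[C@@H](O)[C@H]2OC(C)=O)[C@H]1O`, a disaccharide bearing an octyl glycoside, a hexanoyl ester and two acetates, with a free hydroxyl on the second sugar. In a functional assay on NCI-H460 cells (Homo sapiens) for antiproliferative activity, read by MTT assay, with a stated time of 48 h (a lower number here means a stronger inhibitor, a higher number a weaker inhibitor), compound 1 gives only a limit of the assay, > 500000 nM. Compound 2 `CCCCCCCCO[C@@H]1O[C@@H](C)[C@H](OC(=O)CCCCC)[C@@H](O[C@@H]2O[C@@H](C)[C@H](OC(C)=O)[C@@H](OC(=O)C(C)C)[C@H]2OC(C)=O)[C@H]1O` carries an isopropylcarbonyl group in place of that hydrogen; in this assay compound 2 gives 47000 nM. Among the compounds with values here, the step of an at least 10-fold lower number from compound 1 to compound 2 (1.02 log units; beyond the scatter) is the one measured step in this set. Compound 1 contributes a limit rather than a number, (the limit of > 500000 nM in this assay, at which 1 of the 2 values shown sits). Within the data shown here, compound 2 therefore stands as the only compound with a number in this assay.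

Compound 3 `CCCCCCCCO[C@@H]1O[C@@H](C)[C@H](OC(=O)CCCCC)[C@@H](O[C@@H]2O[C@@H](C)[C@H](OC(C)=O)[C@@H](OC(=O)CC(C)C)[C@H]2OC(C)=O)[C@H]1O` differs from compound 2 by isobutyl in place of isopropyl on a carbonyl carbon. Among the measured compounds shown here, the one measured step concerns the presence or absence of an acyl group at this position, not its shape, so it gives no direct guide to exchanging isopropyl for isobutyl; the expected step of a 1.2-fold lower number from compound 2 to compound 3 (0.07 log units; within the scatter) is small and within the usual scatter. Compound 3 is therefore expected to give 40000 nM, with a range from 15000 nM to 120000 nM.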

Compound 3, half-maximal inhibitory concentration: 79000 nM
Compound 3: the middle estimate sits 2.0-fold (0.30 log units) below what was measured; measured number inside the range.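

In this assay, exchanging isopropyl for isobutyl on a carbonyl carbon gives a 1.7-fold higher number from compound 2 to compound 3 (0.23 log units; within the scatter), so this assay does not separate the two acyl groups, and the shape change tested here has no readable effect. Compound 3 also shows that the effect of acylating the free hydroxyl is not confined to the isopropylcarbonyl group: putting isobutylcarbonyl in place of that hydrogen gives an at least 6.3-fold lower number from compound 1 to compound 3 (0.80 log units; beyond the scatter), so two different acyl groups now stand apart from the free hydroxyl of compound 1. Compound 1 enters this comparison only as a limit of the assay, not as a number, which makes the size of that step a bound: the limit of > 500000 nM in this assay, at which 1 of the 3 values shown sits.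

As far as these compounds go, it remains open whether a straight hexanoyl chain, a smaller acetyl group or a benzoyl group on this oxygen would read the same as isopropylcarbonyl and isobutylcarbonyl. Equally open, from the compounds shown here alone, is whether an amine or a carboxylic acid carried on the acyl chain would keep the activity seen with compound 2 and compound 3 or lose it.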